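This account rests on a few compounds, and the source may have more. Where it says the series, first, only, none or still open, it means among the compounds named here.

Working notes on the series, all with the shared core and a varied aryl group on the sulfonamide nitrogen. In a functional assay on M21 cells (Homo sapiens) for antiproliferative activity, read by sulforhodamine B assay, with a stated time of 48 h (on this read-out higher numbers stand for weaker inhibition and lower numbers for stronger inhibition), compound 3 (`Cc1cc(C)cc(NS(=O)(=O)c2ccc(N3CCNC3=O)cc2)c1`) gives 63 nM, compound 1 (`Cc1ccc(NS(=O)(=O)c2ccc(N3CCNC3=O)cc2)cc1C`) gives 94 nM and compound 2 (`O=C1NCCN1c1ccc(S(=O)(=O)Nc2cccc(Br)c2)cc1`) gives 59 nM. Compound 3 therefore stands within the scatter of both other compounds, and the three numbers do not separate.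

The next compound is compound 4 (`O=C1NCCN1c1ccc(S(=O)(=O)Nc2ccc(Cl)cc2)cc1`), with 4-chlorophenyl in place of 3,5-dimethylphenyl on a sulfonamide nitrogen.

Three measured steps change the group at this same place. They are a 1.6-fold lower number from compound 1 to compound 2 (0.20 log units; within the scatter), a 1.5-fold lower number from compound 1 to compound 3 (0.17 log units; within the scatter) and a 1.1-fold higher number from compound 2 to compound 3 (0.03 log units; within the scatter). Among the measured compounds shown here, all three stay within the scatter, and no measured compound goes against this small set. None of these compounds carries 4-chlorophenyl, however, so the steps bear on the new group only indirectly.

On this evidence, no change beyond the scatter is expected in this assay, and no firm direction can be assigned. The expected change is a 1.1-fold higher number from compound 3 to compound 4 (0.05 log units; within the scatter), which is a step within the scatter. The estimated value for compound 4 is 70 nM, expected to fall between 30 nM and 170 nM.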

Compound 4, half-maximal inhibitory concentration: 90 nM
For compound 4 the middle estimate is 1.3-fold (0.11 log units) below the measured one, within the range that was stated.
By their numbers in this assay, from the lowest: compounds 2, 3, 4 and 1 (each within the scatter of the next).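

In this assay the new group, 4-chlorophenyl on a sulfonamide nitrogen, gives a 1.4-fold higher number from compound 3 to compound 4 (0.15 log units; within the scatter) and a 1.5-fold higher number from compound 2 to compound 4 (0.18 log units; within the scatter) and also a 1.0-fold lower number from compound 1 to compound 4 (0.02 log units; within the scatter) so that it separates from none of the three earlier compounds. This place now holds four aryl groups, with methyl, bromine or chlorine on the ring, and every pair among compounds 1 to 4 stays within the scatter, so neither the kind of ring substituent nor its printed place in these names sorts the series. No measurement is at hand that would explain even these small steps.

Still open, as far as these compounds go, is whether the numbers stay this close once the aryl ring carries an amine or a carboxylic acid, or once a longer chain stands on the sulfonamide nitrogen in place of the aryl group. Also open, from the compounds shown here alone, is whether the four aryl groups stay equally close in cells other than those of this assay and on a core other than the shared one.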